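Lengthening the fluorinated tail of compound 3

A few compounds are considered here, and "the series" means these few. Any claim that something is new, unique, unknown or untested is made for them only; others in the source may bear on it.

In a functional assay on SW1573 cells (Homo sapiens) for inhibition, read by sulforhodamine B assay, with a stated time of 48 h (on this read-out lower numbers stand for stronger inhibition of growth and higher numbers for weaker inhibition of growth), compound 1 (`O=C(CCC(F)(F)C(F)(F)C(F)(F)C(F)(F)C(F)(F)C(F)(F)F)NCCCCCCCCCN[C@@H]1[C@H](O)[C@@H](O)[C@H](O)[C@H]2COC(=O)N21`) gives 14000 nM and compound 3 (`O=C(CCC(F)(F)C(F)(F)C(F)(F)C(F)(F)C(F)(F)C(F)(F)F)NCCCCCCCCCN[C@@H]1[C@H](O)[C@@H](O)[C@@H](O)[C@H]2COC(=O)N21`) gives 14000 nM at the same level. Compound 2 (`O=C(CCC(F)(F)C(F)(F)C(F)(F)C(F)(F)C(F)(F)C(F)(F)C(F)(F)C(F)(F)F)NCCCCCCCCCN[C@@H]1[C@H](O)[C@@H](O)[C@H](O)[C@H]2COC(=O)N21`) reads > 100000 nM as a limit of the assay and not as a number.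

Compound 4 (`O=C(CCC(F)(F)C(F)(F)C(F)(F)C(F)(F)C(F)(F)C(F)(F)C(F)(F)C(F)(F)F)NCCCCCCCCCN[C@@H]1[C@H](O)[C@@H](O)[C@@H](O)[C@H]2COC(=O)N21`) is still unmeasured. It differs from compound 3 by 1,1,2,2,2-pentafluoroethyl in place of fluoro on a saturated chain carbon bound to two fluorine atoms and a saturated chain carbon with 1,1,2,2,2-pentafluoroethyl in place of fluoro on a saturated chain carbon bound to two fluorine atoms and a saturated chain carbon. The only measured case of this exchange is an at least 7.1-fold higher number from compound 1 to compound 2 (0.85 log units; beyond the scatter) and it counts as a lower bound on the size. The other measured step is no change at the digits printed from compound 1 to compound 3 (within the scatter) with the fact that compounds 1 and 3 differ only in the configuration as drawn as the whole difference, so the exchange is expected to carry over to the configuration of compound 3.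

A step of similar size toward weaker inhibition of growth is therefore expected in this assay and may end at the limit of the assay. The expected step is a 7.1-fold higher number from compound 3 to compound 4 (0.85 log units; beyond the scatter) in all. For compound 4 the estimated value is 100000 nM with a range from 40000 nM to 300000 nM and a good chance of a limit only.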

Compound 4, concentration for 50% growth inhibition: > 100000 nM
Compound 4 ended at the assay's limit; the forecaster's own chance of this, stated with the estimate: 70%; the middle value sits exactly at the limit.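

In this assay, the exchange of fluoro for 1,1,2,2,2-pentafluoroethyl on a saturated chain carbon bound to two fluorine atoms and a saturated chain carbon now gives an at least 7.1-fold higher number from compound 3 to compound 4 (0.85 log units; beyond the scatter), so the weakening no longer rests on a single pair. The change reads alike with either drawn configuration at the ring stereocentre: the same change on two cores in this assay, an at least 7.1-fold higher number (0.85 log units; beyond the scatter) from compound 1 to compound 2 and an at least 7.1-fold higher number (0.85 log units; beyond the scatter) from compound 3 to compound 4; the limit leaves it open whether they differ. As far as these compounds go, its true size stays unknown, and the step between compound 2 and compound 4 cannot be read: the limit of > 100000 nM in this assay, at which 2 of the 4 values shown sit.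

From the compounds shown here alone, whether the configuration at this ring carbon matters with the longer tail stays open: the fact that compounds 2 and 4 differ only in the configuration as drawn. Also open, going by these compounds, is how a shorter perfluoroalkyl chain, a plain alkyl chain or a terminal carboxylic acid in place of the fluorinated tail would read in this assay.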